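The source may report more compounds than this note shows. Statements on the series, on what has been measured and on what is new or still open speak of the compounds shown alone.

Among the measured compounds shown here, compound 2 `O=C(N/N=C/c1ccc2no[n+]([O-])c2c1)c1ccccc1O` stands lowest of the two numbers so far in a physicochemical assay for lipophilicity, read by HPLC, measured as octanol-water partition (a higher number here means a more lipophilic compound, a lower number a more polar compound), where compound 2 gives 1.3; compound 1 `Nc1ccccc1C(=O)N/N=C/c1ccc2no[n+]([O-])c2c1` gives 2. Compound 3 `Nc1cccc(C(=O)N/N=C/c2ccc3no[n+]([O-])c3c2)c1` has not yet been measured in this assay. It differs from compound 2 by 3-aminophenyl in place of 2-hydroxyphenyl on a carbonyl carbon. For the measured compounds named here, the one measured step that bears on it is a number 0.70 log units lower from compound 1 to compound 2 (beyond the scatter), an exchange of amino for hydroxy in the opposite direction. A step back upward of about that size is expected, a number 0.60 log units higher from compound 2 to compound 3 (beyond the scatter), though compound 1 is not itself a 3-aminophenyl, so that step is only a partial guide. Compound 3 is therefore estimated at 1.9, within 1.4 to 2.4.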

Compound 3, partition coefficient: 1.4
Beside the measured number, compound 3's estimate is 0.50 log units above it; the measured number falls inside the stated range.
By their numbers in this assay, from the lowest: compounds 2 and 3 (each within the scatter of the next); then compound 1.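

The change from 2-aminophenyl to 3-aminophenyl on a carbonyl carbon shows that in this assay the place of the amino group alone matters (a number 0.60 log units lower from compound 1 to compound 3 (beyond the scatter)). The other new step stays within the scatter (a number 0.10 log units higher from compound 2 to compound 3 (within the scatter)), so 3-aminophenyl and 2-hydroxyphenyl cannot be told apart at this position. The earlier exchange of amino and hydroxy therefore holds for 2-aminophenyl and 2-hydroxyphenyl only.

Nothing here gives a reason for either step. On these data alone, how a 3-hydroxyphenyl or a methoxy-bearing phenyl would read on the same carbonyl carbon remains open.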